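Swapping 2,6-Dichlorophenyl for 3-Bromophenyl on a Shared Core

The source may report more compounds than this note shows. Statements on the series, on what has been measured and on what is new or still open speak of the compounds shown alone.

In an ADME assay on Vero cells (Chlorocebus sabaeus) for inhibition (on this read-out lower numbers stand for higher toxicity in this test and higher numbers for lower toxicity in this test), compound 1 (`COc1ccc(/C=C2\CCC/C(=C\c3ccccc3)C2=O)cc1`) gives 291000 nM, compound 2 (`COc1ccc(/C=C2\CCC/C(=C\c3ccccc3Cl)C2=O)cc1`) gives 238000 nM and compound 3 (`COc1ccc(/C=C2\CCC/C(=C\c3c(Cl)cccc3Cl)C2=O)cc1`) gives 232000 nM. Compound 3 therefore stands within the scatter of both other compounds, and the three numbers show no order. Compound 4 (`COc1ccc(/C=C2\CCC/C(=C\c3cccc(Br)c3)C2=O)cc1`) differs from compound 3 by 3-bromophenyl in place of 2,6-dichlorophenyl on a double-bonded chain carbon bound to a double-bonded ring carbon, with 3-bromophenyl in place of 2,6-dichlorophenyl on a double-bonded chain carbon bound to a double-bonded ring carbon. For the measured compounds named here, three measured steps bear on this change, all of them changes to the same aromatic ring: a 1.2-fold lower number from compound 1 to compound 2 (0.09 log units; within the scatter), a 1.3-fold lower number from compound 1 to compound 3 (0.10 log units; within the scatter) and a 1.0-fold lower number from compound 2 to compound 3 (0.01 log units; within the scatter). Going by the values given here, none leaves the scatter, although none of the measured compounds carries a bromine, so the evidence is indirect. No shift beyond the scatter is therefore expected, and the estimated step is a 1.0-fold higher number from compound 3 to compound 4 (0.01 log units; within the scatter). Compound 4 is estimated at 240000 nM, with an expected range from 140000 nM to 400000 nM.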

Compound 4, half-maximal cytotoxic concentration: 30000 nM
Beside the measured number, compound 4's estimate is 8.0-fold (0.90 log units) above it; measured number below the stated range.
By their numbers in this assay, from the lowest: compound 4; then compounds 3, 2 and 1 (each within the scatter of the next).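

The earlier compounds shown here suggested that changes to this aromatic ring barely register in this assay, since the chloro groups of compound 2 and compound 3 stay within the scatter of compound 1. The 3-bromophenyl group shows otherwise, with a 9.7-fold lower number from compound 1 to compound 4 (0.99 log units; beyond the scatter) for a single bromo in place of hydrogen, alongside a 7.9-fold lower number from compound 2 to compound 4 (0.90 log units; beyond the scatter) and a 7.7-fold lower number from compound 3 to compound 4 (0.89 log units; beyond the scatter) on replacing the chlorinated rings, so the ring on this double-bonded chain carbon does affect the read-out. Nothing available here accounts for this shift.

The compounds shown leave open whether the shift belongs to the bromine itself or to where it sits on the ring. A 3-chlorophenyl, 2-bromophenyl or 4-bromophenyl group at this place would separate those two readings.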